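The source may hold more compounds than are shown below. What is called first, only, known or untested is meant among the compounds shown, and "the series" means these compounds.

Measured in a functional assay on ECa-109 cells for inhibition, with ECa-109 cell line (Homo sapiens) as the target, read by MTT assay, with a stated time of 48 h; a higher number here means a weaker inhibitor, a lower number a stronger inhibitor:
- compound 1 `COc1ccc(-c2coc3cc(OCCCSC(=S)N4CCN(C)CC4)ccc3c2=O)cc1`: 24200 nM
- compound 2 `COc1ccc(-c2coc3cc(OCCCSC(=S)N4CCN(C(C)=O)CC4)ccc3c2=O)cc1`: 24700 nM
- compound 3 `COc1ccc(-c2coc3cc(OCCCSC(=S)N4CCN(C(=O)OC(C)(C)C)CC4)ccc3c2=O)cc1`: 3540 nM

Compound 1 stands level with compound 2 at the high end of these numbers, and compound 3 lies apart as the most potent of the three. Compound 4 `COc1ccc(-c2coc3cc(OCCCCBr)ccc3c2=O)cc1` differs from compound 1 by one change: a group of 2 heavy atoms (1 carbon, 1 bromine; no ring) in place of a group of 10 heavy atoms (6 carbon, 2 nitrogen, 2 sulfur; one six-membered non-aromatic ring with 2 hetero atoms), on a saturated chain carbon, three bonds along the chain from an oxygen on an aromatic ring.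

The measured steps alter only the far end of the group that compound 4 loses. One stays within the scatter, a 1.0-fold higher number from compound 1 to compound 2 (0.01 log units; within the scatter). The two others are modest, a 6.8-fold lower number from compound 1 to compound 3 (0.83 log units; beyond the scatter) and a 7.0-fold lower number from compound 2 to compound 3 (0.84 log units; beyond the scatter). None removes the whole group, so they offer only a rough guide. No step beyond the scatter is expected, though the uncertainty is wide. The estimated step is a 1.2-fold higher number from compound 1 to compound 4 (0.09 log units; within the scatter). For compound 4 the expected value is 30000 nM, with an estimated range of 8000 nM to 100000 nM.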

Compound 4, half-maximal inhibitory concentration: 66300 nM
For compound 4 the middle estimate is 2.2-fold (0.34 log units) below the measured one, within the range that was stated.
By their numbers in this assay, from the lowest: compound 3; then compounds 1 and 2 (each within the scatter of the next); then compound 4.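

Where the earlier steps changed only the far end of the group on the chain, this one replaces the whole group carrying the six-membered ring with bromomethyl, giving a 2.7-fold higher number from compound 1 to compound 4 (0.44 log units; beyond the scatter) and so a weaker inhibitor. Even so, compound 4 still gives a number, 66300 nM, so activity in this set does not depend entirely on that group. Nothing available here explains this shift. Still open, from the compounds shown here alone, is where an amine, a carboxylic acid or a longer chain in this place would fall relative to compound 1 and compound 4.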